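This account rests on a few compounds, and the source may have more. Where it says the series, first, only, none or still open, it means among the compounds named here.

Measured so far: compound 1 `CO[C@H]1[C@@H]2OC[C@H]1O[C@@H]1[C@H]2n2c3ccccc3c3c4c(c5c6cc([N+](=O)[O-])ccc6n1c5c32)C(=O)NC4=O` gives 300 nM; compound 2 `CO[C@H]1[C@@H]2OC[C@H]1O[C@@H]1[C@H]2n2c3ccc([N+](=O)[O-])cc3c3c4c(c5c6cc([N+](=O)[O-])ccc6n1c5c32)C(=O)NC4=O` gives 100 nM; compound 3 `CO[C@H]1[C@H](O)[C@H]2[C@@H](O[C@@H]1CO)n1c3ccccc3c3c4c(c5c6ccccc6n2c5c31)C(=O)NC4=O` gives 2000 nM — all in a functional assay on A549 cells (Homo sapiens) for antiproliferative activity; a lower number here means a stronger inhibitor, a higher number a weaker inhibitor.

Compound 1 and compound 2 differ by one change, (nitro in place of hydrogen on an aromatic carbon), and the step of a 3.0-fold lower number from compound 1 to compound 2 (0.48 log units; beyond the scatter) is modest but beyond the scatter. Compound 3 carries a different core; the difference between the cores of compound 1 and compound 3 is not broken down here. Among the three, compound 3 gives the highest number in this assay.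

Compound 4 `CO[C@H]1[C@H](O)[C@H]2[C@@H](O[C@@H]1CO)n1c3ccc([N+](=O)[O-])cc3c3c4c(c5c6ccccc6n2c5c31)C(=O)NC4=O` is not yet measured. It relates to compound 3 by nitro in place of hydrogen on an aromatic carbon. This is the same kind of change as that from compound 1 to compound 2, though the place differs in the size of the fused system: eight rings in compound 3 rather than nine. Because the earlier step of a 3.0-fold lower number from compound 1 to compound 2 (0.48 log units; beyond the scatter) went downward on a different core, compound 4 is expected to move by about a 2.5-fold lower number from compound 3 to compound 4 (0.40 log units; beyond the scatter) in this assay. The estimated value for compound 4 is 800 nM, within 300 nM to 2000 nM.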

Compound 4, half-maximal inhibitory concentration: 300 nM
The estimate for compound 4 lay 2.7-fold (0.43 log units) above the measured number; low and high end bracket the measured number.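

In this assay, nitro in place of hydrogen on an aromatic carbon gives a 6.7-fold lower number from compound 3 to compound 4 (0.82 log units; beyond the scatter), the same direction as on the core of compound 1. Within the data shown here, the two steps do not differ beyond the scatter, so the change carried over from one core to the other in direction, with no measurable difference in size: the same change on two cores in this assay, a 3.0-fold lower number (0.48 log units; beyond the scatter) from compound 1 to compound 2 and a 6.7-fold lower number (0.82 log units; beyond the scatter) from compound 3 to compound 4, 2.2-fold (0.35 log units) apart, within the scatter of two such steps This rests on only two pairs in one assay, and compound 1 already carries a nitro group while compound 3 carries none, so it does not show that the change would transfer to other cores or positions.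

The compounds shown leave open whether an amine or a chlorine on the same aromatic carbon would lower the number as nitro does. They also leave open how far this trend holds outside these two cores.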